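The compounds below may be only part of what the source reports. "The series", "measured", "known", "first", "only" and "open" are said of these compounds alone.

Compound 1, `COCCOC(=O)C(O)Cn1cnc2c(N)ncnc21`, gives in a functional assay on Vero cells (Chlorocebus sabaeus) for cytotoxicity (on this read-out higher numbers stand for lower toxicity in this test and lower numbers for higher toxicity in this test), the value > 400 ug/mL, which is a limit of the assay and not a number.
Compound 2, `CC(C)COC(=O)C(O)Cn1cnc2c(N)ncnc21`, gives in this assay the value > 400 ug/mL, again a limit.
Compound 3, `CC(C)(C)OC(=O)C(O)Cn1cnc2c(N)ncnc21`, gives in this assay the value > 400 ug/mL, also a limit.

Compound 3 therefore stands at the limit of > 400 ug/mL in this assay, at which 3 of the 3 values shown sit, and nothing among the three values sets it apart. The steps that lead to it, a step that the two limits leave unreadable from compound 1 to compound 3 and a step that the two limits leave unreadable from compound 2 to compound 3, are both unreadable, as is a step that the two limits leave unreadable from compound 1 to compound 2 between the other two; every change of the ester group tried so far has left the read-out at the limit.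

Compound 4, `CC(C)CCOC(=O)C(O)Cn1cnc2c(N)ncnc21`, differs from compound 3 in one place: isopentyl in place of tert-butyl on an oxygen next to a carbonyl group. The measured steps that bear on this are the three ester exchanges just named, and none of them gave a readable size or direction. On that basis the change from compound 3 to compound 4 is expected to give no step beyond the scatter, and the expected step is a number no higher from compound 3 to compound 4 (the limit leaves the size open). Compound 4 is expected to come out at about 400 ug/mL, within a range from 200 ug/mL to 1000 ug/mL, most likely again reported only as a limit.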

Compound 4, minimum cytotoxic concentration: 400 ug/mL
Estimate against measurement, compound 4: no gap at the digits printed, and the stated range covers the measured number.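

Going by these compounds alone, compound 4, with isopentyl in place of tert-butyl on an oxygen next to a carbonyl group, is the first of these esters to give a number in this assay (compound 4: 400 ug/mL) and not a limit, and that number marks the edge of the range the other esters are reported against: the limit of > 400 ug/mL in this assay, at which 3 of the 4 values shown sit.

The comparisons with the three earlier esters carry a direction at most and no size: the data give a number no higher from compound 3 to compound 4 (the limit leaves the size open) and a number no higher from compound 2 to compound 4 (the limit leaves the size open) and also a number no higher from compound 1 to compound 4 (the limit leaves the size open) in the same assay.

So the change to isopentyl is the first at this position to leave a reading on the scale, yet whether it truly separates compound 4 from the other esters cannot be read from these values.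

What stands open is how a longer chain, a benzyl group or a chain ending in an amine would read on this oxygen in this assay and whether any of them would give a number clearly lower than that of compound 4 (400 ug/mL). As far as these compounds go, the free carboxylic acid in place of the ester is equally open.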